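A Methoxyphenyl Swap on the Alkene of Compound 1

The source may hold more compounds than are shown below. What is called first, only, known or untested is meant among the compounds shown, and "the series" means these compounds.

Compound 1, `Cc1cc(C)cc(/C=C(\C(=O)c2ccc(Cl)cc2)S(=O)(=O)c2ccc(Br)cc2)c1`, was tested in a functional assay on DU-145 cells (Homo sapiens) for inhibition, read by trypan blue exclusion, with a stated time of 96 h; on this read-out lower numbers stand for stronger inhibition of growth and higher numbers for weaker inhibition of growth. In that assay compound 1 gives 10000 nM, the highest of the three numbers measured. Compound 2, `O=C(O)c1ccc(C(=O)/C(=C\c2ccc(F)c([N+](=O)[O-])c2)SCc2ccc(F)cc2)cc1`, gives 1000 nM, and compound 3, `Cc1cc(C)cc(/C=C(\C(=O)c2ccc(Cl)cc2)S(=O)(=O)Cc2ccc(Cl)cc2)c1`, gives 1000 nM. Going by the values given here, the only step between compounds that differ in one place runs from compound 1 to compound 3, where a 10-fold lower number from compound 1 to compound 3 (1.00 log units; beyond the scatter).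

Compound 4, `COc1ccccc1/C=C(\C(=O)c1ccc(Cl)cc1)S(=O)(=O)c1ccc(Br)cc1`, differs from compound 1 as follows: 2-methoxyphenyl in place of 3,5-dimethylphenyl on a double-bonded chain carbon bound to a double-bonded chain carbon. Among the compounds with values here, that change sits on the double-bonded chain carbon bound to a double-bonded chain carbon, while the one measured step alters the group on the sulfonyl sulfur, so it does not bear on the change at hand. Within the data shown here, no measured pair shows what exchanging the aryl group on the alkene does. With nothing to point either way, the number for compound 4 is expected to stay close to that of compound 1, with no change at the digits printed from compound 1 to compound 4 (within the scatter) expected to fall within the scatter. Compound 4 is therefore estimated at 10000 nM, expected between 3000 nM and 30000 nM.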

Compound 4, concentration for 50% growth inhibition: 10000 nM
For compound 4 middle estimate and measured number coincide at the digits printed; measured number inside the range.
By their numbers in this assay, from the lowest: compounds 2 and 3 (each within the scatter of the next); then compounds 1 and 4 (each within the scatter of the next).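

Putting 2-methoxyphenyl in place of 3,5-dimethylphenyl on a double-bonded chain carbon bound to a double-bonded chain carbon gives no change at the digits printed from compound 1 to compound 4 (within the scatter) in this assay. Going by these compounds alone, this is the first measured pair that changes this position, and it shows that, with the 4-bromophenyl group kept on the sulfonyl sulfur, this exchange of one aryl group for another, which adds one hydrogen-bond acceptor, leaves the number in place, whereas the change on the sulfonyl sulfur gave a 10-fold lower number from compound 1 to compound 3 (1.00 log units; beyond the scatter). No measurement on hand accounts for this result.

As far as these compounds go, whether an amine or a longer chain at this place would shift the number remains open. So does whether the 2-methoxyphenyl exchange would also leave the number in place with the 4-chlorobenzyl group of compound 3 on the sulfonyl sulfur.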